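Working notes on compound 4: dimethylamino in place of fluoro

The compounds below may be only part of what the source reports. "The series", "measured", "known", "first", "only" and "open" are said of these compounds alone.

The series shares one core and varies the aryl group on a carbon with a double bond to nitrogen. In a functional assay on the whole organism (strain Wistar) for inhibition, with Rattus norvegicus as the target, read by paw edema, with a stated time of 2 h, at a dose of 10 mg/kg by the intraperitoneal route (a higher number here means more inhibition at the dose given (going by the name of the read-out), a lower number less inhibition), compound 1 `O=C(N/N=C/c1cccc(F)c1)c1cccnc1Nc1cccc(C(F)(F)F)c1` gives 52.8%. Compound 2 `O=C(N/N=C/c1ccc(F)cc1)c1cccnc1Nc1cccc(C(F)(F)F)c1` gives 41.2% in this assay, the lowest of the three numbers: a number 11.6 percentage points lower from compound 1 to compound 2 (beyond the scatter) is beyond the scatter, while a number 3.5 percentage points higher from compound 2 to compound 3 (within the scatter) is within it. Compound 3 `COc1ccc(/C=N/NC(=O)c2cccnc2Nc2cccc(C(F)(F)F)c2)c(OC)c1` gives 44.7% in this assay; a number 8.1 percentage points lower from compound 1 to compound 3 (within the scatter) is also within the scatter.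

Compound 4 `CN(C)c1ccc(/C=N/NC(=O)c2cccnc2Nc2cccc(C(F)(F)F)c2)cc1` is not yet measured. It differs from compound 2 as follows: dimethylamino in place of fluoro on an aromatic carbon. Among the measured compounds shown here, no measured step exchanges fluoro for dimethylamino, so the bearing steps are indirect. Going from compound 2 to compound 3 also replaces fluoro on this ring with groups carrying hydrogen-bond acceptors and stays within the scatter; the only step beyond the scatter, from compound 1 to compound 2, concerns where the fluoro sits, not what replaces it.

For compound 4 in this assay the estimate is 45%, range 30% to 60%. The expected step is a number 3.8 percentage points higher from compound 2 to compound 4 (within the scatter), not beyond the scatter.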

Compound 4, a percentage reported as inhibition, in the whole organism at one dose (the size of the read-out at that dose, not a potency): 51.4%
Beside the measured number, compound 4's estimate is 6.4 percentage points below it; the range from low to high includes it.
By their numbers in this assay, from the lowest: compounds 2, 3, 4 and 1 (each within the scatter of the next, the first and the last beyond it).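

In this assay, among the compounds shown here, dimethylamino in place of fluoro, para to a large group, gives a number 10.2 percentage points higher from compound 2 to compound 4 (beyond the scatter): the first step beyond the scatter that replaces the fluoro on this aromatic carbon rather than moving it. The 4-fluorophenyl group therefore does not set the level for groups at this place, yet the gain does not separate compound 4 from the other two neighbours, since a number 6.7 percentage points higher from compound 3 to compound 4 (within the scatter) and a number 1.4 percentage points lower from compound 1 to compound 4 (within the scatter) both stay within the scatter. No measurement alongside these numbers bears on what lies behind the step.

Whether the step belongs to dimethylamino itself or would follow from other replacements of fluoro at this place remains open, as the compounds shown include no primary amine, morpholine or carboxylic acid there. Also open, going by these compounds, is whether the same exchange would do anything on the 3-fluorophenyl group of compound 1, and whether the step would hold at another dose or read-out time, since everything here rests on a single dose and a single time.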